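From 4-aminophenoxy to 4-fluorophenoxy in the series

A few compounds are considered here, and "the series" means these few. Any claim that something is new, unique, unknown or untested is made for them only; others in the source may bear on it.

Of the compounds shown here, three with a shared core have numbers so far in a functional assay on MIA PaCa-2 cells (Homo sapiens) for cytotoxicity, read by MTT assay, with a stated time of 4 h (a higher number here means a weaker inhibitor, a lower number a stronger inhibitor), and all sit close together. Compound 1 (`COC1=CC(=O)c2c(c(COc3c(F)cc(F)cc3F)c(C)n2C)C1=O`) gives 427 nM in this measurement, compound 2 (`COC1=CC(=O)c2c(COc3ccc(N)cc3)c(C)n(C)c2C1=O`) gives 504 nM and compound 3 (`COC1=CC(=O)c2c(COc3ccc([N+](=O)[O-])cc3F)c(C)n(C)c2C1=O`) gives 529 nM on the same read-out. Compound 2 stands within the scatter of both compound 1 and compound 3, so these values set no order among the three.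

The next compound is compound 4 (`COC1=CC(=O)c2c(COc3ccc(F)cc3)c(C)n(C)c2C1=O`), which is related to compound 2 by a single change: fluoro in place of amino on an aromatic carbon (fluoro in place of amino on an aromatic carbon, para to a large group). Among the measured compounds shown here, no pair of measured compounds differs in one place, so the size of this change in this assay has no direct precedent. The expectation rests only on the narrow spread of the three values: compound 1 at 427 nM and compound 3 at 529 nM both carry fluoro on the aromatic ring of the side chain and remain within the scatter of compound 2 at 504 nM in this series. The expected size of a 1.1-fold lower number from compound 2 to compound 4 (0.02 log units; within the scatter) lies within the scatter, with no direction expected. Compound 4 is estimated at 480 nM with an expected range from 240 nM to 950 nM in this assay when measured.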

Compound 4, half-maximal inhibitory concentration: 905 nM
Beside the measured number, compound 4's estimate is 1.9-fold (0.28 log units) below it; low and high end bracket the measured number.
By their numbers in this assay, from the lowest: compounds 1, 2, 3 and 4 (each within the scatter of the next, the first and the last beyond it).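

Notes on the 4-aminophenoxy to 4-fluorophenoxy change: in this assay, the series now has its only one-place comparison, a 1.8-fold higher number from compound 2 to compound 4 (0.25 log units; within the scatter), for fluoro in place of amino on an aromatic carbon, para to a large group. This exchange swaps a group counted with one hydrogen-bond donor and one hydrogen-bond acceptor for a group counted with neither, yet the step does not separate the two compounds on this read-out, so no effect of the change can be claimed from this single pair. No supporting measurement is available to interpret this step.

As far as these compounds go, it remains open whether another group at this place, such as methoxy, a carboxylic acid, a dimethylamino group or a longer alkyl chain, would give a step beyond the scatter in this assay. From the compounds shown here alone, it is also open whether fluoro in place of amino would give a step of similar size on a side-chain ring that carries further substituents, since one pair cannot establish a trend for this position across the series.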